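The source may report more compounds than this note shows. Statements on the series, on what has been measured and on what is new or still open speak of the compounds shown alone.

Measured so far:
- Compound 1, `C=C1[C@@H](OC(C)=O)C[C@@H]2[C@](C)(COC=O)[C@H](OC(C)=O)CC[C@@]2(C)[C@@H]1C[C@@H](Nc1ccc(OC)c(OC)c1)C1=CCOC1=O`: in a functional assay on MCF7 cells (Homo sapiens) for cytotoxicity, read by sulforhodamine B assay (a higher number here means a weaker inhibitor, a lower number a stronger inhibitor), compound 1 gives > 50000 nM, which is a limit of the assay rather than a number.
- Compound 2, `C=C1[C@@H](OC(C)=O)C[C@@H]2[C@](C)(COC=O)[C@H](OC(C)=O)CC[C@@]2(C)[C@@H]1C[C@@H](Nc1cccc2ccccc12)C1=CCOC1=O`: in this assay compound 2 gives 9750 nM.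

Compound 2 therefore holds the only true number shown; the other value is a limit, (the limit of > 50000 nM in this assay, at which 1 of the 2 values shown sits). Compound 3, `C=C1[C@@H](OC(C)=O)C[C@@H]2[C@](C)(COC=O)[C@H](OC(C)=O)CC[C@@]2(C)[C@@H]1C[C@@H](Nc1ccc(C(=O)O)cc1)C1=CCOC1=O`, differs from compound 2 by one change: 4-carboxyphenyl in place of naphthalen-1-yl on an amine nitrogen. Among the measured compounds shown here, the one measured step that bears on this change is an at least 5.1-fold lower number from compound 1 to compound 2 (0.70 log units; beyond the scatter), in which naphthalen-1-yl in place of 3,4-dimethoxyphenyl on the amine nitrogen gave a number that was at least modestly lower. Compound 3 reverses that direction, leaving naphthalen-1-yl for a single six-membered ring again, now 4-carboxyphenyl, so a rise in the number back toward the limit, and beyond the scatter, is expected in this assay. Compound 3 is estimated at 30000 nM, between 8000 nM and 100000 nM, an expected step of a 3.1-fold higher number from compound 2 to compound 3 (0.49 log units; beyond the scatter).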

Compound 3, half-maximal inhibitory concentration: 41700 nM
Compound 3: middle estimate off by 1.4-fold (0.14 log units), on the low side; the range from low to high includes it.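

In this assay, replacing naphthalen-1-yl on the amine nitrogen with 4-carboxyphenyl gives a 4.3-fold higher number from compound 2 to compound 3 (0.63 log units; beyond the scatter), so a second single-ring group also falls well short of naphthalen-1-yl on the shared core. The earlier gain is therefore not tied to 3,4-dimethoxyphenyl alone. Compound 1 carries a limit rather than a number, so the remaining comparison, an at least 1.1-fold lower number from compound 1 to compound 3 (0.07 log units; that floor lies within the scatter), cannot put the two single-ring compounds in order: the limit of > 50000 nM in this assay, at which 1 of the 3 values shown sits.

This change removes a ring and adds a carboxylic acid in one move, and the compounds shown do not separate those two differences. A plain phenyl group, or a methyl ester in place of the carboxylic acid, would help to tell them apart.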